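From 4-fluorobenzyl to 3-(trifluoromethyl)benzyl

A few compounds are considered here, and "the series" means these few. Any claim that something is new, unique, unknown or untested is made for them only; others in the source may bear on it.

Compound 1 `O=C(CN[C@H]1CCN(S(=O)(=O)Cc2ccccc2)C1)N1CCN(Cc2cccc(Cl)c2)CC1` gives 8600 nM
Compound 2 `O=C(CN[C@H]1CCN(S(=O)(=O)Cc2ccccc2)C1)N1CCN(Cc2ccccc2F)CC1` gives 12600 nM
Compound 3 `O=C(CN[C@H]1CCN(S(=O)(=O)Cc2ccccc2)C1)N1CCN(Cc2ccc(F)cc2)CC1` gives 14300 nM

In a functional assay on K562 cells (Homo sapiens) for cytotoxicity, read by MTT assay, with a stated time of 48 h (on this read-out lower numbers stand for stronger inhibition and higher numbers for weaker inhibition), compound 3 gives 14300 nM and stands within the scatter of the other two, as a 1.7-fold higher number from compound 1 to compound 3 (0.22 log units; within the scatter) and a 1.1-fold higher number from compound 2 to compound 3 (0.05 log units; within the scatter) show. Compound 4 `O=C(CN[C@H]1CCN(S(=O)(=O)Cc2ccccc2)C1)N1CCN(Cc2cccc(C(F)(F)F)c2)CC1` carries one change, (3-(trifluoromethyl)phenyl in place of 4-fluorophenyl on a saturated chain carbon bound to an amine nitrogen in a ring), which is 3-(trifluoromethyl)phenyl in place of 4-fluorophenyl on a saturated chain carbon bound to an amine nitrogen in a ring. Every measured exchange at that place, including a 1.5-fold higher number from compound 1 to compound 2 (0.17 log units; within the scatter), stayed within the scatter, so no step beyond it is expected. The closest guide is compound 1, which has 3-chlorophenyl there and gives 8600 nM in this assay. The expected step, within the scatter, is a 1.4-fold lower number from compound 3 to compound 4 (0.16 log units; within the scatter). Compound 4 is estimated at 10000 nM, with an expected range of 5000 nM to 20000 nM.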

Compound 4, half-maximal inhibitory concentration: 3600 nM
Compound 4: middle estimate off by 2.8-fold (0.44 log units), on the high side; measured number below the stated range.
By their numbers in this assay, from the lowest: compound 4; then compounds 1, 2 and 3 (each within the scatter of the next).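

In this assay, 3-(trifluoromethyl)phenyl on a saturated chain carbon bound to an amine nitrogen in a ring gives a 4.0-fold lower number from compound 3 to compound 4 (0.60 log units; beyond the scatter) and a 3.5-fold lower number from compound 2 to compound 4 (0.54 log units; beyond the scatter), so this place does respond to its substituent, which no earlier exchange there showed. With 3-chlorophenyl as the starting point, trifluoromethyl in place of chloro still gives a 2.4-fold lower number from compound 1 to compound 4 (0.38 log units; beyond the scatter), which sets compound 4 apart from all three others. Nothing available accounts for this step. From the compounds shown here alone, whether a nitrile, a methoxy group or a bromo group in place of trifluoromethyl on an aromatic carbon would match compound 4 stays open, as does whether the step carries over to another core.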